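Swapping octyl for 3-chlorophenyl in a growth-inhibition series

A few compounds are considered here, and "the series" means these few. Any claim that something is new, unique, unknown or untested is made for them only; others in the source may bear on it.

In a functional assay on NUGC-3 cells (Homo sapiens) for cytotoxicity, read by sulforhodamine B assay, with a stated time of 72 h (a lower number here means a stronger inhibitor of growth, a higher number a weaker inhibitor of growth), compound 1 (`O=C(Nc1cc(C(F)(F)F)cc(C(F)(F)F)c1)C1CCc2ccccc2N1C(=O)c1ccccc1Cl`) gives 1930 nM as its result. Compound 2 (`CC(=O)N1c2ccccc2CCC1C(=O)Nc1cc(C(F)(F)F)cc(C(F)(F)F)c1`) gives > 70000 nM and this is a limit of the assay, not a number. Compound 3 (`CCCCCCCCC(=O)N1c2ccccc2CCC1C(=O)Nc1ccccc1C(F)(F)F`) gives 6180 nM and so holds the higher of the two real numbers, with compound 1 lower by more than the scatter.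

Compound 4 (`O=C(Nc1ccccc1C(F)(F)F)C1CCc2ccccc2N1C(=O)c1cccc(Cl)c1`) carries 3-chlorophenyl in place of octyl on a carbonyl carbon whose other neighbour is an amide-type nitrogen in a ring (3-chlorophenyl in place of octyl on a carbonyl carbon). For the measured compounds named here, the one measured step at this place is large (an at least 36-fold higher number from compound 1 to compound 2 (1.55 log units; beyond the scatter)) but it brings in methyl, which compound 4 does not carry. Compound 1 with 2-chlorophenyl there reads 1930 nM and compound 3 with octyl reads 6180 nM so both give real numbers, unlike the methyl case. The expected step is therefore small (a 1.4-fold lower number from compound 3 to compound 4 (0.14 log units; within the scatter)) and would stay within the scatter. In this assay compound 4 is estimated at 4500 nM with an expected range from 1500 nM to 15000 nM for now.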

Compound 4, concentration for 50% growth inhibition: 754 nM
For compound 4 the middle estimate is 6.0-fold (0.78 log units) above the measured one; measured number below the stated range.
By their numbers in this assay, from the lowest: compound 4; then compound 1; then compound 3. At a limit, above all of these: compound 2.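

In this assay, putting 3-chlorophenyl in place of octyl on a carbonyl carbon, with the rest of the molecule unchanged, gives an 8.2-fold lower number from compound 3 to compound 4 (0.91 log units; beyond the scatter). For the compounds shown here, the only earlier step at this place ended at a limit of the assay, so this is the first step here with a real number at both ends, and it shows that an aromatic ring can give a clearly lower number than a long chain, at least in this one pair. Nothing measured here gives a reason for this step.

This single pair cannot separate the contribution of the ring from that of its chlorine, so a plain phenyl would be the telling comparison. From the compounds shown here alone, whether a shorter chain such as butyl, or a group carrying an amine, would read nearer compound 3 or compound 4 also remains open.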